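Swapping chloro for methylsulfanyl on a nicotine-like core

The source may report more compounds than this note shows. Statements on the series, on what has been measured and on what is new or still open speak of the compounds shown alone.

Measured compounds:
- compound 1 `CC(=O)c1ccc(/C=C2\CCCN=C2c2cccnc2)cc1`: 4490 nM
- compound 2 `C(=C1\CCCN=C1c1cccnc1)\c1ccc(-n2ccnn2)cc1`: 520 nM
- compound 3 `Clc1ccc(/C=C2\CCCN=C2c2cccnc2)cc1`: 970 nM

All three share one core and differ only in the group on the far aromatic ring. In an assay on membranes from brain for displacement of a labelled ligand from Neuronal acetylcholine receptor; alpha4/beta2 (Rattus norvegicus), with a stated time of 3 h (a higher number here means a weaker inhibitor, a lower number a stronger inhibitor), compound 1 gives 4490 nM, compound 2 gives 520 nM and compound 3 gives 970 nM. Compound 3 thus sits second highest of the three numbers, close to compound 2 and well away from compound 1: a 1.9-fold higher number from compound 2 to compound 3 (0.27 log units; within the scatter), while a 4.6-fold lower number from compound 1 to compound 3 (0.67 log units; beyond the scatter).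

Compound 4 `CSc1ccc(/C=C2\CCCN=C2c2cccnc2)cc1` is the next step: methylsulfanyl in place of chloro on an aromatic carbon. Within the data shown here, no measured step involves methylsulfanyl, so the known steps bear on it only indirectly. They show that two quite different groups at this position, in compound 2 and compound 3, give numbers within the scatter of each other, and that only acetyl in compound 1 stands apart. On that basis no step beyond the scatter is expected in this assay, and compound 4 is estimated at 900 nM, with a range from 350 nM to 2500 nM, which means an expected step of a 1.1-fold lower number from compound 3 to compound 4 (0.03 log units; within the scatter).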

Compound 4, inhibition constant: 900 nM
Compound 4: the middle estimate sits on the measured number at the digits printed; measured number inside the range.
By their numbers in this assay, from the lowest: compounds 2, 4 and 3 (each within the scatter of the next); then compound 1.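

In this assay, methylsulfanyl in place of chloro gives a 1.1-fold lower number from compound 3 to compound 4 (0.03 log units; within the scatter) and, set against the triazolyl group, gives a 1.7-fold higher number from compound 2 to compound 4 (0.24 log units; within the scatter) so a third, different group now falls within the scatter of the other two at this position. Among these compounds, the chlorine atom can thus give way to a carbon and a sulfur with no step that can be told from the scatter. Acetyl remains the only group apart, with a 5.0-fold lower number from compound 1 to compound 4 (0.70 log units; beyond the scatter) and this now holds against three other groups rather than two. No measurement shown here accounts for this result.

Going by these compounds, whether an amine, a carboxylic acid or a longer chain at this position would stay with these three groups or stand apart like acetyl remains open. Also open, on these data alone, is what these same groups would do elsewhere on the ring, since all four compounds carry theirs para to a large group.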